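Swapping methoxy for cyano on a weak pyridine analogue

This account rests on a few compounds, and the source may have more. Where it says the series, first, only, none or still open, it means among the compounds named here.

Of the compounds shown here, three have been tested in a functional assay on HEK293 cells for agonist activity at Neuronal acetylcholine receptor; alpha3/beta4 (Homo sapiens), read by FLIPR; on this read-out lower numbers stand for an effect already at smaller amounts and higher numbers for an effect only at larger amounts of compound. Compound 1 `c1cncc(N2CC[C@@H]3CN[C@@H]3C2)c1` gives 260 nM. Compound 2 `COc1cc(N2C[C@@H]3CCNC[C@@H]32)cnc1Br` gives 2980 nM, the highest number of the three; compound 3 `COc1cc(N2C[C@H]3CCNC[C@H]32)cnc1Br`, its mirror image, gives 202 nM. Within the data shown here, the one measured step, a 15-fold lower number from compound 2 to compound 3 (1.17 log units; beyond the scatter), is a large one, and it rests on (the fact that compounds 2 and 3 differ only in the configuration as drawn), so it says nothing about swapping a substituent on the ring.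

Compound 4 `N#Cc1cc(N2C[C@@H]3CCNC[C@@H]32)cnc1Br` is not yet measured. It differs from compound 2 by cyano in place of methoxy on an aromatic carbon. Among the measured compounds shown here, no measured step in this set involves such a change of substituent, so there is no direct guide to its size or direction. In this assay the step of a 1.0-fold higher number from compound 2 to compound 4 (0.00 log units; within the scatter) is therefore expected to stay within the usual scatter, with a broad margin for surprise. On that basis compound 4 is estimated at 3000 nM, within a range from 700 nM to 13000 nM.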

Compound 4, half-maximal effective concentration: 794 nM
For compound 4 the middle estimate is 3.8-fold (0.58 log units) above the measured one; low and high end bracket the measured number.
By their numbers in this assay, from the lowest: compounds 3 and 1 (each within the scatter of the next); then compound 4; then compound 2.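

Swapping the substituent at this spot, two atoms from the ring nitrogen and ortho to a bromo group, changes the result in this assay: cyano in place of methoxy gives a 3.8-fold lower number from compound 2 to compound 4 (0.57 log units; beyond the scatter), a modest step that lies beyond the scatter. Among these compounds, this is the first measured change of a group on the aromatic ring, as the only earlier step separated two mirror images. Methoxy and cyano have the same counts of heavy atoms and hydrogen-bond acceptors, so those counts do not tell the two groups apart, and nothing measured here explains this step.

As far as these compounds go, whether the same swap would move the number in the same direction on the mirror-image core of compound 3 remains open. From the compounds shown here alone, how other groups at this position, such as an amine, a carboxylic acid or a longer ethoxy chain, would compare is also open.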